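The source may report more compounds than this note shows. Statements on the series, on what has been measured and on what is new or still open speak of the compounds shown alone.

Measured compounds:
compound 1 `CCCSc1nc(N)c2nc(O)n(Cc3ccccc3)c2n1` – 0.01 uM
compound 2 `Nc1ncnc2c1nc(O)n2Cc1ccc(Cl)cc1` – 10 uM
compound 3 `NNc1nc2c(N)ncnc2n1Cc1ccccc1` – > 10 uM

The read-out here is a functional assay (spleen, spleen) for activation, with Mus musculus as the target; on this read-out lower numbers stand for an effect already at smaller amounts and higher numbers for an effect only at larger amounts of compound. Of the two numbers recorded, compound 1 gives the lowest, at 0.01 uM. Its nearest neighbour among the numbers is compound 2 with 10 uM, a gap that lies well beyond the scatter of repeated runs. Compound 3 has no number at all: its result, > 10 uM, is a limit of this assay, and the limit of > 10 uM in this assay, at which 1 of the 3 values shown sits, records it as such.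

The next compound to enter this assay is compound 4, `Nc1nc(S)nc2c1nc(O)n2Cc1ccccc1`. It differs from compound 1 in one place only: hydrogen in place of propyl on a sulfur. For the measured compounds named here, no pair of measured compounds separated by a single change is available, so the size of this step can only be expected, not read off. The account here expects that cutting the propyl back to a bare sulfanyl moves the number upward, that is, toward an effect only at larger amounts, by a step clearly beyond the scatter, written as a 100-fold higher number from compound 1 to compound 4 (2.00 log units; beyond the scatter).

On this basis compound 4 is estimated to give 1 uM in this assay, with a plausible range from 0.1 uM to 10 uM.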

Compound 4, minimum effective concentration: 10 uM
Beside the measured number, compound 4's estimate is 10-fold (1.00 log units) below it, and the stated range covers the measured number.
By their numbers in this assay, from the lowest: compound 1; then compounds 2 and 4 (each within the scatter of the next).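

For the compounds shown here, the pair gives the first single-place reading in this assay: with hydrogen in place of propyl on a sulfur, the read-out shows a 1000-fold higher number from compound 1 to compound 4 (3.00 log units; beyond the scatter). It shows that the group on this sulfur is not a bystander, since the propylsulfanyl form carries the low number of compound 1 at 0.01 uM and the bare sulfanyl form does not keep it. Compound 4 also sits at the edge of what this read-out records as a number, so any further upward change from it might not be readable as a size: the limit of > 10 uM in this assay, at which 1 of the 4 values shown sits.

From the compounds shown here alone, what stays open is how the number follows the chain on this sulfur, that is, whether a methyl, an ethyl or a longer chain such as butyl or hexyl would keep it low or whether propyl is a special case. Also open, going by these compounds, is whether the sulfur itself matters, which an oxygen or an amine carrying the same propyl in its place would begin to answer.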